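The source may hold more compounds than are shown below. What is called first, only, known or untested is meant among the compounds shown, and "the series" means these compounds.

In a functional assay on A-375 cells (Homo sapiens) for antiproliferative activity, read by CCK-8 assay, with a stated time of 72 h, tested at 8 uM (on this read-out higher numbers stand for a stronger effect at the one concentration tested and lower numbers for a weaker effect), the three measured compounds give the following numbers:

Compound 1 `Nc1ccccc1NC(=O)c1ccc(CSC(=S)N2CCN(Cc3ccncc3)CC2)cc1`: 89.5%
Compound 2 `COc1ccc(N2CCN(C(=S)SCc3ccc(C(=O)Nc4ccccc4N)cc3)CC2)cc1`: 35.9%
Compound 3 `Nc1ccccc1NC(=O)c1ccc(CSC(=S)N2CCN(c3ccncc3)CC2)cc1`: 90.7%

Compound 3 holds the top number of the three, yet the step of a number 1.2 percentage points higher from compound 1 to compound 3 (within the scatter) lies within the scatter, so compound 1 and compound 3 cannot be told apart; only compound 2 is clearly lower, as the step of a number 54.8 percentage points higher from compound 2 to compound 3 (beyond the scatter) shows. Compound 4 `Nc1ccccc1NC(=O)c1ccc(CSC(=S)N2CCN(c3ncccn3)CC2)cc1` carries one change against compound 3: pyrimidin-2-yl in place of pyridin-4-yl on an amine nitrogen in a ring. Among the compounds with values here, no measured step swaps one aromatic group on this ring nitrogen for another of the same kind. The step of a number 54.8 percentage points higher from compound 2 to compound 3 (beyond the scatter) shows that an aromatic group here can shift this assay by a large amount, while a number 1.2 percentage points higher from compound 1 to compound 3 (within the scatter) shows a change here can also leave it untouched. A small drop or no step beyond the scatter is therefore expected, a number 10.7 percentage points lower from compound 3 to compound 4 (beyond the scatter). Compound 4 is estimated at 80%, between 45% and 95%.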

Compound 4, a percentage reported as inhibition, at one concentration (the size of the read-out at that concentration, not a potency): 67.9%
For compound 4 the middle estimate is 12.1 percentage points above the measured one, within the range that was stated.
By their numbers in this assay, from the lowest: compound 2; then compound 4; then compounds 1 and 3 (each within the scatter of the next).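

Exchanging one six-membered aromatic ring for another of equal heavy-atom count, with a second ring nitrogen entering, still changes the result in this assay, giving a number 22.8 percentage points lower from compound 3 to compound 4 (beyond the scatter) and showing that even this small swap on the ring nitrogen counts. The same group gives a number 21.6 percentage points lower from compound 1 to compound 4 (beyond the scatter) and also a number 32 percentage points higher from compound 2 to compound 4 (beyond the scatter), so the two steps to this group run in opposite directions. Nothing available here explains these differences. On these data alone, how a plain phenyl or a pyridin-2-yl group on this nitrogen would compare remains open.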